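A halogen-bearing phenyl in place of the dimethoxyphenyl

The source may hold more compounds than are shown below. What is called first, only, known or untested is meant among the compounds shown, and "the series" means these compounds.

Compound 1 `COc1ccc(C(=O)NC2CCN(Cc3ccc4ccccc4c3)CC2)cc1OC` stands weakest of the three measured compounds: in an assay on isolated protein for binding affinity to melanin-concentrating hormone receptor 1 (Homo sapiens) (on this read-out lower numbers stand for stronger inhibition and higher numbers for weaker inhibition), compound 1 gives 1000 nM. Compound 2 `COc1cc(C(=O)NC2CCN(Cc3ccc4ccccc4c3)CC2)cc(OC)c1OC` gives 286 nM, and compound 3 `O=C(NC1CCN(Cc2ccc3ccccc3c2)CC1)c1ccc(F)c(F)c1` gives 18 nM. Compound 4 `O=C(NC1CCN(Cc2ccc3ccccc3c2)CC1)c1ccc(Cl)cc1` differs from compound 1 in one place: 4-chlorophenyl in place of 3,4-dimethoxyphenyl on a carbonyl carbon. Among the measured compounds shown here, two measured steps bear on this change. Adding a single methoxy gave a 3.5-fold lower number from compound 1 to compound 2 (0.54 log units; beyond the scatter), a modest gain. Exchanging the whole 3,4-dimethoxyphenyl for a 3,4-difluorophenyl gave a 56-fold lower number from compound 1 to compound 3 (1.74 log units; beyond the scatter), a large gain. Compound 4 also exchanges the 3,4-dimethoxyphenyl for a halogen-bearing phenyl, so a large step to a lower number is expected, a 25-fold lower number from compound 1 to compound 4 (1.40 log units; beyond the scatter). Compound 4 is therefore estimated to give 40 nM, with a likely range from 10 nM to 160 nM.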

Compound 4, inhibition constant: 232 nM
The estimate for compound 4 lay 5.8-fold (0.76 log units) below the measured number; measured number above the stated range.
By their numbers in this assay, from the lowest: compound 3; then compounds 4 and 2 (each within the scatter of the next); then compound 1.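

Exchanging the 3,4-dimethoxyphenyl for a 4-chlorophenyl gives a 4.3-fold lower number from compound 1 to compound 4 (0.63 log units; beyond the scatter), only a modest gain. The gap between the two halogen-bearing phenyls is large, with a 13-fold higher number from compound 3 to compound 4 (1.11 log units; beyond the scatter), so on this carbonyl carbon a halogen alone does not guarantee the gain seen with 3,4-difluorophenyl. Nothing available here explains this gap. As far as these compounds go, compounds 3 and 4 differ in both the kind and the number of halogens, so their separate contributions remain open. A 4-fluorophenyl or a 3,4-dichlorophenyl on the same carbonyl carbon would help to separate them.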